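From a Six-Membered to a Five-Membered Ring on Oxygen

A few compounds are considered here, and "the series" means these few. Any claim that something is new, unique, unknown or untested is made for them only; others in the source may bear on it.

Within the data shown here, compound 1 `CCOCc1nnc(N2C[C@@H]3C[C@]3(c3ccc(F)cc3Cl)C2)n1-c1ccc(OC)nc1` is the only anchor with a number: in a functional assay on HEK293 cells for antagonist activity at Vasopressin V2 receptor (Homo sapiens), read by cAMP accumulation, with a stated time of 30 min (on this read-out lower numbers stand for stronger inhibition and higher numbers for weaker inhibition), compound 1 gives 7320 nM, a weak result on this read-out. Compound 2 `COc1ccc(-n2c(COC3CCOCC3)nnc2N2C[C@@H]3C[C@]3(c3ccc(F)cc3Cl)C2)cn1` shares the same core but carries an oxan-4-yl group on the oxygen of its side chain; in this assay compound 2 gives "not determined" (no result reported), so where it stands is simply not known, and the difference between compound 1 and compound 2 cannot be read at all. Compound 3 `COc1ccc(-n2c(CO[C@H]3CCOC3)nnc2N2C[C@@H]3C[C@]3(c3ccc(F)cc3Cl)C2)cn1` differs from compound 2 in one place: oxolan-3-yl in place of oxan-4-yl on an oxygen on a saturated carbon. The one six-membered non-aromatic ring leaves and the one five-membered non-aromatic ring enters on the same oxygen, with the same count of hydrogen-bond acceptors and no charge. Among the measured compounds shown here, since no measured step exists for comparison, no change beyond the usual scatter of this assay is expected from this exchange, in either direction. Resting only on the value of compound 1 and allowing wide uncertainty, compound 3 is expected to give about 5000 nM in this assay, within a range from 1500 nM to 20000 nM.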

Compound 3, half-maximal inhibitory concentration: 23000 nM
Beside the measured number, compound 3's estimate is 4.6-fold (0.66 log units) below it; the whole stated range lies below it.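

In this assay, placing oxolan-3-yl instead of ethyl on the oxygen gives a 3.1-fold higher number from compound 1 to compound 3 (0.50 log units; beyond the scatter) and so weaker inhibition, a modest change but the first measured sign that this position responds to what the oxygen carries. For this one pair, the ring does not improve on the small open chain, although compound 1 and compound 3 both remain weak on this read-out. The exchange of oxan-4-yl for oxolan-3-yl itself cannot be read, as compound 2 has no reported result, and nothing measured here accounts for the rise in the number.

The compounds shown leave open whether any group on this oxygen could bring the number down from that of compound 1, for example a methyl group, a longer chain such as propyl, or a chain ending in an amine. They also leave open whether the opposite stereocentre of the oxolan-3-yl group would behave as compound 3 does.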